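Trifluoromethyl in place of methoxy: notes on compound 3

The source may report more compounds than this note shows. Statements on the series, on what has been measured and on what is new or still open speak of the compounds shown alone.

In a functional assay on MDA-MB-231 cells (Homo sapiens) for antiproliferative activity, read by MTT assay, with a stated time of 72 h (on this read-out higher numbers stand for weaker inhibition and lower numbers for stronger inhibition), compound 2 (`COc1ccccc1Nc1cccc2c1S(=O)(=O)C=C2`) gives 2400 nM and compound 1 (`O=S1(=O)C=Cc2cccc(Nc3c(F)c(F)c(F)c(F)c3F)c21`) gives 4460 nM on the same read-out. For the measured compounds named here, these two values lie within the scatter of each other, so compound 2 stands level with compound 1 on the numbers so far, and the pair sets no order.

The next entry is compound 3 (`O=S1(=O)C=Cc2cccc(Nc3ccccc3C(F)(F)F)c21`), which has trifluoromethyl in place of methoxy on an aromatic carbon, ortho to a large group (trifluoromethyl in place of methoxy on an aromatic carbon).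

Going by the values given here, no measured pair differs in one place only, so this change has no direct precedent. Among the compounds with values here, the only guide is the narrow spread of the two values in hand, although the two compounds carry different groups on the shared core. On that basis, no step beyond the scatter is expected in this assay, with only a slight lean towards weaker inhibition. The estimated step is a 1.3-fold higher number from compound 2 to compound 3 (0.10 log units; within the scatter) and it stays within the scatter.

For compound 3 the estimate is 3000 nM with an expected range from 1000 nM to 9000 nM as the working figure.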

Compound 3, half-maximal inhibitory concentration: 3900 nM
Estimate against measurement, compound 3: 1.3-fold (0.11 log units) below; the range from low to high includes it.
By their numbers in this assay, from the lowest: compounds 2, 3 and 1 (each within the scatter of the next).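

For the compounds shown here, the pair of compound 2 and compound 3 is the first to differ in one place only, and in this assay it gives a 1.6-fold higher number from compound 2 to compound 3 (0.21 log units; within the scatter). Going by these compounds alone, at this position, on an aromatic carbon ortho to a large group, methoxy (2 heavy atoms, 1 hydrogen-bond acceptor) can therefore give way to trifluoromethyl (4 heavy atoms, 0 hydrogen-bond acceptors) with no step that can be told from the scatter, so this one exchange shows the read-out staying level across two groups that differ in size and in acceptor count. Nothing at hand bears on why the two groups read alike.

Still open, from the compounds shown here alone, is whether the read-out stays level at this position with a group of another kind, such as an amine, a carboxylic acid or a longer chain. Also open, going by these compounds, is whether the same exchange of methoxy for trifluoromethyl reads the same on an aromatic carbon elsewhere on the ring, or when the shared core is altered.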